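This account rests on a few compounds, and the source may have more. Where it says the series, first, only, none or still open, it means among the compounds named here.

Measured compounds:
compound 1, `Nc1ccccc1NC(=O)c1ccc(CSc2nccc(C(F)(F)F)n2)cc1`: 80.1%
compound 2, `Nc1ccccc1NC(=O)/C=C/c1ccc(CSc2ccc(F)cc2)cc1`: 24.6%

In a functional assay on A-375 cells (Homo sapiens) for inhibition, read by CCK-8 assay, with a stated time of 72 h, tested at 8 uM (on this read-out lower numbers stand for less inhibition of growth and higher numbers for more inhibition of growth at the one concentration tested), compound 1 gives 80.1%. Compound 2 gives 24.6% in the same test. Within the data shown here, compound 2 therefore stands lowest of the two numbers known, and its nearest neighbour, compound 1, lies far higher, beyond the usual scatter. Among the measured compounds shown here, the two measured compounds differ in more than one place, so no single change can be tied to that gap; the pair shows only that compound 2 inhibits growth much less than compound 1.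

Compound 3, `CCc1ccc(SCc2ccc(/C=C/C(=O)Nc3ccccc3N)cc2)cc1`, has not yet been tested. It differs from compound 2 in one place: ethyl in place of fluoro on an aromatic carbon. For the measured compounds named here, nothing among the measured compounds carries this same change, so its effect is not known. The step from compound 2 to compound 3 is expected to be small, staying within the scatter, as a number 5.4 percentage points higher from compound 2 to compound 3 (within the scatter) shows. Compound 3 is estimated at 30%, within a range from 12% to 55%.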

Compound 3, percent growth inhibition at one concentration: 58.4%
Compound 3: middle estimate off by 28.4 percentage points, on the low side; measured number outside the range, above it.
By their numbers in this assay, from the lowest: compound 2; then compound 3; then compound 1.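

In this assay, turning the 4-fluorophenyl group into a 4-ethylphenyl group gives a number 33.8 percentage points higher from compound 2 to compound 3 (beyond the scatter), so this one position, on an aromatic carbon para to a large group, clearly matters for growth inhibition. The earlier pair could not show this, since compound 1 and compound 2 differ in more than one place, whereas here a single exchange of fluoro for ethyl accounts for the whole step. Nothing available explains why ethyl gives the higher number here.

On these data alone, whether a longer chain such as propyl, or an amine, on the same aromatic carbon would raise the number further or lower it remains open. This is also a single step from one pair of compounds, so it leaves open whether ethyl would have a similar effect on a different core.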